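Cytotoxicity notes: from compound 1 to compound 4

The source may report more compounds than this note shows. Statements on the series, on what has been measured and on what is new or still open speak of the compounds shown alone.

Compound 1 `COc1ccc([C@H]2CC(=O)N(c3cc(N)cc(N)c3)C2)cc1OC1CCCC1` — in a functional assay on HEK293 cells (Homo sapiens) for cytotoxicity (on this read-out higher numbers stand for lower toxicity in this test and lower numbers for higher toxicity in this test), compound 1 reaches only the limit > 10000 nM.
Compound 2 `COc1ccc([C@H]2CC(=O)N(c3cccc(C)c3)C2)cc1OC1CCCC1` — in this assay compound 2 likewise reaches only the limit > 10000 nM.
Compound 3 `COc1ccc([C@H]2CC(=O)N(c3ccc(C)cc3)C2)cc1OC1CCCC1` — in this assay compound 3 also sits at the limit > 10000 nM.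

Compound 1 thus stands at a limit, not at a number, and every value shown sits at the same limit (the limit of > 10000 nM in this assay, at which 3 of the 3 values shown sit). The step to compound 4 `COc1ccc([C@H]2CC(=O)N(c3cccnc3)C2)cc1OC1CCCC1` is pyridin-3-yl in place of 3,5-diaminophenyl on an amide-type nitrogen in a ring. The measured steps on the amide-type nitrogen in a ring, a step that the two limits leave unreadable from compound 1 to compound 2, a step that the two limits leave unreadable from compound 1 to compound 3 and a step that the two limits leave unreadable from compound 2 to compound 3, are all unreadable between two limits, so neither size nor direction can be read from them. No step beyond the scatter is therefore expected in this assay. Compound 4 is expected to give 20000 nM, within 10000 nM to 50000 nM. The step so estimated is a step that the limit leaves unreadable from compound 1 to compound 4.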

Compound 4, half-maximal cytotoxic concentration: > 10000 nM
Compound 4 gave a limit, no number; the forecaster's own chance of this, stated with the estimate: 85%; the middle value is on the limit's open side.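

In this assay compound 4 gives > 10000 nM, a limit and not a number. Its steps from compound 1, compound 2 and compound 3 therefore cannot be read. The compounds shown leave open whether any group on the amide-type nitrogen changes cytotoxicity at all: the limit of > 10000 nM in this assay, at which 4 of the 4 values shown sit.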